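Fluoro Placed on the Phenyl Ring: Cytotoxicity Outlook

A few compounds are considered here, and "the series" means these few. Any claim that something is new, unique, unknown or untested is made for them only; others in the source may bear on it.

Compound 3 `O=C(c1ccc2c(c1)OCCO2)C1CCN(Cc2coc(-c3ccccc3)n2)CC1` carries an unsubstituted phenyl ring on the shared core. In an ADME assay on HEK293 cells (Homo sapiens) for cytotoxicity, read by MTT assay, with a stated time of 36 h (on this read-out higher numbers stand for weaker inhibition and lower numbers for stronger inhibition), compound 3 gives > 150 ug/mL, which is a limit of the assay rather than a number. Compound 1 `O=C(c1ccc2c(c1)OCCO2)C1CCN(Cc2coc(-c3ccc(F)cc3)n2)CC1` carries a fluoro on that ring. In this assay compound 1 gives > 150 ug/mL, again a limit. Compound 2 `O=C(c1ccc2c(c1)OCCO2)C1CCN(Cc2coc(-c3ccc(Cl)cc3)n2)CC1` carries a chloro instead. In this assay compound 2 gives > 150 ug/mL, also a limit. All three values sit at the same place, (the limit of > 150 ug/mL in this assay, at which 3 of the 3 values shown sit). The step from compound 1 to compound 2 reads a step that the two limits leave unreadable from compound 1 to compound 2, the step from compound 1 to compound 3 reads a step that the two limits leave unreadable from compound 1 to compound 3, and the step from compound 2 to compound 3 reads a step that the two limits leave unreadable from compound 2 to compound 3. Both ends of each of these steps are limits, and no size can be read from them.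

Compound 4 `O=C(c1ccc2c(c1)OCCO2)C1CCN(Cc2coc(-c3ccccc3F)n2)CC1` differs from compound 3 by fluoro in place of hydrogen on an aromatic carbon. Every measured change on this ring has left the value at the limit, so the step expected from compound 3 to compound 4 is a step that the limit leaves unreadable from compound 3 to compound 4, nothing beyond the scatter. Compound 4 is therefore estimated at 200 ug/mL, within a range from 120 ug/mL to 400 ug/mL, and the assay is expected most likely to report only a limit once more.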

Compound 4, half-maximal inhibitory concentration: > 150 ug/mL
Compound 4: a limit, no number (the forecaster's own chance of this, stated with the estimate: 85%); the middle value does not contradict the limit.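

In this assay compound 4 gives > 150 ug/mL, which is a limit and not a number. From the compounds shown here alone, the steps to compound 4 from compound 1, compound 2 and compound 3 therefore cannot be read, because all four compounds share one limit: the limit of > 150 ug/mL in this assay, at which 4 of the 4 values shown sit. What stays open is how far any of these four compounds differs from the others in cytotoxicity.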